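Ortho nitro to chloro swap in the series

The source may report more compounds than this note shows. Statements on the series, on what has been measured and on what is new or still open speak of the compounds shown alone.

Measured in a functional assay on T98G cells (Homo sapiens) for cytotoxicity, read by MTT assay, with a stated time of 48 h; a higher number here means a weaker inhibitor, a lower number a stronger inhibitor:
- compound 1 `C/C(=N/NC(=S)Nc1ccccc1)c1ccccn1` gives 6.81 nM
- compound 2 `C/C(=N/NC(=S)Nc1ccccc1[N+](=O)[O-])c1ccccn1` gives 6.61 nM

Only these two compounds have been measured, and compound 2 lies within the scatter of compound 1, so the two values give no order. For the measured compounds named here, compound 2 therefore stands level with the only other measured member of the series.

The next entry, compound 3 `C/C(=N/NC(=S)Nc1ccccc1Cl)c1ccccn1`, carries chloro in place of nitro on an aromatic carbon of a six-membered aromatic ring of carbon only, ortho to a large group (chloro in place of nitro on an aromatic carbon).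

Going by the values given here, one measured step bears on this change, at the same place on the ring: a 1.0-fold lower number from compound 1 to compound 2 (0.01 log units; within the scatter). That step, nitro in place of hydrogen, stayed within the scatter. Among the compounds with values here, no chloro compound has been measured, so this single step is the only guide. It gives no reason to expect a shift in either direction.

The expected result in this assay is no change beyond the scatter, with an estimated step of a 1.1-fold lower number from compound 2 to compound 3 (0.03 log units; within the scatter).

The estimate for compound 3 is 6.2 nM, with an expected range from 2.5 nM to 15 nM.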

Compound 3, half-maximal inhibitory concentration: 1.1 nM
Compound 3: middle estimate off by 5.6-fold (0.75 log units), on the high side; measured number outside the range, below it.
By their numbers in this assay, from the lowest: compound 3; then compounds 2 and 1 (each within the scatter of the next).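

In this assay this place on the aromatic ring proves responsive to substitution, which the first pair did not show: chloro in place of hydrogen gives a step beyond the scatter (a 6.2-fold lower number from compound 1 to compound 3 (0.79 log units; beyond the scatter)), while nitro at the same place stayed within it (a 1.0-fold lower number from compound 1 to compound 2 (0.01 log units; within the scatter)). The direct exchange of the two groups gives a step of similar size (a 6.0-fold lower number from compound 2 to compound 3 (0.78 log units; beyond the scatter)), so the outcome at this place depends on which group sits there, and a substituent here cannot be treated as neutral on the strength of nitro alone. Nothing available accounts for the lower number with chloro, and the counted differences between nitro and chloro in heavy atoms and hydrogen-bond acceptors remain a description of the change, not an explanation of it.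

Hydrogen, nitro and chloro are the only groups shown at this place, so it remains open whether the lower number is particular to chloro or extends to other groups such as fluoro, bromo, methyl or an amine. Also open, on these data alone, is whether chloro elsewhere on the same ring gives a comparable step, and whether this step carries over to any cell line other than the one tested here.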